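Notes on a fluoro step in a small series

The source may report more compounds than this note shows. Statements on the series, on what has been measured and on what is new or still open speak of the compounds shown alone.

Measured in an ADME assay on Vero cells (Chlorocebus sabaeus) for cytotoxicity, read by MTT assay, with a stated time of 72 h; a higher number here means that more compound is tolerated, a lower number that less compound is tolerated:
compound 1 `CCOC(=O)c1c(-c2ccc(OC)cc2)oc2ccc(OCCCCCCN3C(=O)/C(=N\OC)c4cc(F)ccc43)cc12` gives 16 ug/mL
compound 2 `CCOC(=O)c1c(-c2ccc(OC)cc2)oc2ccc(OCCCCCCN3C(=O)/C(=N\NC(N)=S)c4ccccc43)cc12` gives 8 ug/mL

Only these two numbers are available so far in this assay. Among the compounds with values here, compound 2 stands at 8 ug/mL, and its only neighbour, compound 1 at 16 ug/mL, lies within the scatter of it, so the two values set no order.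

The next compound to be read is compound 3 `CCOC(=O)c1c(-c2ccc(OC)cc2)oc2ccc(OCCCCCCN3C(=O)/C(=N\NC(N)=S)c4cc(F)ccc43)cc12`, which is compound 2 with a single change: fluoro in place of hydrogen on an aromatic carbon. This is fluoro in place of hydrogen on an aromatic carbon of a six-membered aromatic ring of carbon only.

Within the data shown here, no measured pair isolates this change, so there is no direct step to carry over. Starting from compound 2 at 8 ug/mL, no shift beyond the scatter is expected in this assay, in either direction. The expected size of the change is a 1.3-fold higher number from compound 2 to compound 3 (0.10 log units; within the scatter). For compound 3 the estimated value is 10 ug/mL, with an expected range of 4 ug/mL to 25 ug/mL.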

Compound 3, half-maximal cytotoxic concentration: 8 ug/mL
Compound 3: the middle estimate sits 1.3-fold (0.10 log units) above what was measured; the range from low to high includes it.
By their numbers in this assay, from the lowest: compounds 2, 3 and 1 (each within the scatter of the next).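

In this assay, within the data shown here, the first direct reading of fluoro in place of hydrogen on an aromatic carbon, here on a six-membered aromatic ring of carbon only that is part of a fused system, gives no change at the digits printed from compound 2 to compound 3 (within the scatter), so at this position the change leaves the tolerated concentration within the scatter. Among these compounds, with the fluoro held constant, a second single change can now be read for the first time: the group of 4 heavy atoms in place of the group of 2 heavy atoms on the double-bonded nitrogen gives a 2.0-fold lower number from compound 1 to compound 3 (0.30 log units; within the scatter), which also stays within the scatter. No other measurement bears on either step, and neither step can be tied to a cause.

Open, as far as these compounds go, is whether chloro or trifluoromethyl on the same aromatic carbon would also stay within the scatter, and whether an amine or a carboxylic acid in place of the group on the double-bonded nitrogen would move the number beyond it. Also open, from the compounds shown here alone, is whether a longer chain between the shared core and the fused ring system would shift the number, and whether the fluoro step would hold with such a chain in place.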